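A Sulfonyl Replacement on the Amine Nitrogen, Cytotoxicity Expected

The source may report more compounds than this note shows. Statements on the series, on what has been measured and on what is new or still open speak of the compounds shown alone.

Compound 1 `N#CC1=C(N)N(c2ccc(S(N)(=O)=O)cc2)C2=C(C(=O)CCC2)C1c1ccc(Cl)cc1Cl`: 50%
Compound 2 `N#CC1=C(NC(=S)Nc2ccccc2)N(c2ccc(S(N)(=O)=O)cc2)C2=C(C(=O)CCC2)C1c1ccc(Cl)cc1Cl`: 50%
Compound 3 `N#CC1=C(NC(=S)Nc2ccc(Br)cc2)N(c2ccc(S(N)(=O)=O)cc2)C2=C(C(=O)CCC2)C1c1ccc(Cl)cc1Cl`: 50%

In a functional assay on Ehrlich cells (Mus musculus) for cytotoxicity, read by trypan blue exclusion, with a stated time of 2 h, tested at 25 ug/mL (on this read-out lower numbers stand for a weaker effect and higher numbers for a stronger effect at the one concentration tested), compound 1 gives 50%, compound 2 gives 50% and compound 3 gives 50%. Compound 3 therefore stands level with the other two, as seen in no change at the digits printed from compound 1 to compound 3 (within the scatter) and no change at the digits printed from compound 2 to compound 3 (within the scatter).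

Compound 4 `N#CC1=C(NS(=O)(=O)c2ccc([N+](=O)[O-])cc2)N(c2ccc(S(N)(=O)=O)cc2)C2=C(C(=O)CCC2)C1c1ccc(Cl)cc1Cl` differs from compound 3 by a group of 12 heavy atoms (6 carbon, 1 nitrogen, 4 oxygen, 1 sulfur; one six-membered aromatic ring of carbon only) in place of a group of 10 heavy atoms (7 carbon, 1 nitrogen, 1 sulfur, 1 bromine; one six-membered aromatic ring of carbon only), on an amine nitrogen. The measured steps that bear on this are the two earlier replacements at the same amine nitrogen, no change at the digits printed from compound 1 to compound 2 (within the scatter) and no change at the digits printed from compound 1 to compound 3 (within the scatter), together with the change within the attached ring, no change at the digits printed from compound 2 to compound 3 (within the scatter); all stayed within the scatter. Compound 4 is accordingly expected to show no step beyond the scatter, no change at the digits printed from compound 3 to compound 4 (within the scatter). The estimate for compound 4 is 50%, expected to fall between 35% and 65%.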

Compound 4, a percentage reported as activity, at one concentration (the size of the read-out at that concentration, not a potency): 85%
The estimate for compound 4 lay 35 percentage points below the measured number, and the stated range ends below it.
By their numbers in this assay, from the lowest: compounds 1, 2 and 3 (each within the scatter of the next); then compound 4.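

Placing (4-nitrophenyl)sulfonyl on the amine nitrogen gives a number 35 percentage points higher from compound 1 to compound 4 (beyond the scatter) in this assay, so the read-out at this position does depend on the attached group. The same holds against the two earlier groups there, with a number 35 percentage points higher from compound 2 to compound 4 (beyond the scatter) and a number 35 percentage points higher from compound 3 to compound 4 (beyond the scatter), although those two had stayed level with the free amine. Nothing measured here gives a reason for this rise.

As far as these compounds go, whether the rise follows the sulfonyl link itself or the nitro group on its ring stays open. A plain phenylsulfonyl or a methylsulfonyl group on this nitrogen would help separate the two.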